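Series notes: hydroxy in place of hydrogen, compound 4

The source may report more compounds than this note shows. Statements on the series, on what has been measured and on what is new or still open speak of the compounds shown alone.

Compound 1 `COc1cccc(CNc2ncnc3c2ncn3[C@@H]2O[C@H](CO)[C@@H](O)[C@H]2O)c1` carries a 3-methoxyphenyl group on the shared core. In a functional assay on HOS cells (Homo sapiens) for antiproliferative activity, with a stated time of 72 h (on this read-out lower numbers stand for stronger inhibition and higher numbers for weaker inhibition), compound 1 gives > 166000 nM, which is a limit of the assay and not a number. Compound 3 `COc1cccc(CNc2ncnc3c2ncn3[C@@H]2O[C@H](CO)[C@@H](O)[C@H]2O)c1O` differs from compound 1 by hydroxy in place of hydrogen on an aromatic carbon. In this assay compound 3 gives > 166000 nM, again a limit of the assay. The step that the two limits leave unreadable from compound 1 to compound 3 therefore cannot be sized, in keeping with the limit of > 166000 nM in this assay, at which 2 of the 3 values shown sit. Compound 2 `COc1cc(CNc2ncnc3c2ncn3[C@@H]2O[C@H](CO)[C@@H](O)[C@H]2O)cc(OC)c1` differs from compound 1 by methoxy in place of hydrogen on an aromatic carbon. In this assay compound 2 gives "not determined" (no result reported). Compound 4 `COc1cc(CNc2ncnc3c2ncn3[C@@H]2O[C@H](CO)[C@@H](O)[C@H]2O)cc(OC)c1O` is not yet measured; it differs from compound 2 by hydroxy in place of hydrogen on an aromatic carbon. This is the same kind of change as that from compound 1 to compound 3, but the surroundings differ: in compound 3 the hydroxy enters ortho to a large group and ortho to a methoxy group, whereas in compound 4 it enters ortho to two methoxy groups and para to a large group. With the earlier step unreadable and compound 2 lacking a result, no step size can be carried over. Compound 4 is expected to sit at the limit as well, resting on (the limit of > 166000 nM in this assay, at which 2 of the 3 values shown sit). Compound 4 is estimated at 200000 nM, with an expected range from 80000 nM to 1000000 nM.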

Compound 4, half-maximal inhibitory concentration: > 166000 nM
Compound 4 gave a limit, no number; the forecaster's own chance of this, stated with the estimate: 85%; the middle value lies beyond the limit too.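

No step can be read from compound 2 to compound 4: the entry for compound 2 gives no number in this assay, and compound 4 gives a limit of the assay, not a number. The compounds shown leave open whether hydroxy in place of hydrogen on an aromatic carbon changes the value in this assay at all: compound 1, compound 3 and compound 4 all stand at the same limit.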